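The source may hold more compounds than are shown below. What is called first, only, known or untested is meant among the compounds shown, and "the series" means these compounds.

- compound 1 `CCC1=C(O)c2c(oc(-c3ccc(OC)cc3)cc2=O)C(CC)(CC)C1=O`: 17.7 uM
- compound 2 `CCC1=C(O)c2c(oc(-c3ccc(Br)cc3)cc2=O)C(CC)(CC)C1=O`: > 48.1 uM (a limit)
- compound 3 `CCC1=C(O)c2c(oc(-c3ccc(CBr)cc3)cc2=O)C(CC)(CC)C1=O`: > 46.5 uM (a limit)

All values come from a functional assay on KB cells (Homo sapiens) for antiproliferative activity, read by sulforhodamine B assay, with a stated time of 3 days; on this read-out higher numbers stand for an effect only at larger amounts of compound and lower numbers for an effect already at smaller amounts. Compound 3 gives no number, only the limit > 46.5 uM.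

Compound 4 `CCC1=C(O)c2c(oc(-c3cccc(C)c3)cc2=O)C(CC)(CC)C1=O` has 3-methylphenyl in place of 4-(bromomethyl)phenyl on an aromatic carbon.

For the measured compounds named here, two measured steps bear on this change: an at least 2.6-fold higher number from compound 1 to compound 3 (0.41 log units; beyond the scatter) and an at least 2.7-fold higher number from compound 1 to compound 2 (0.43 log units; beyond the scatter). Both are at least modest and beyond the scatter. Going by the values given here, the only full number is that of compound 1, at 17.7 uM, so a modest move to a lower number is expected. Another limit remains possible for compound 4. The expected step is an at least 1.6-fold lower number from compound 3 to compound 4 (0.22 log units; that floor lies within the scatter). The estimate for compound 4 is 28 uM, with an expected range of 12 uM to 57 uM.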

Compound 4, concentration for half-maximal effect: 49.7 uM
Compound 4: middle estimate off by 1.8-fold (0.25 log units), on the low side, and the stated range covers the measured number.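

In this assay, the change away from 4-methoxyphenyl now has a readable size against a full number rather than a limit: a 2.8-fold higher number from compound 1 to compound 4 (0.45 log units; beyond the scatter). Compound 1 remains the most active of the four, so 3-methylphenyl does not restore the activity of 4-methoxyphenyl. The steps to compound 4 from compound 2 and from compound 3 cannot be read.

This step changes both the group and its place on the phenyl ring, and the compounds shown do not separate the two. Still open, from the compounds shown here alone, is how a 4-aminophenyl or a 4-carboxyphenyl group would compare with compound 1.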